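The compounds below may be only part of what the source reports. "The series", "measured", "known", "first", "only" and "open" are said of these compounds alone.

Measured in a functional assay on HPAC cells (Homo sapiens) for inhibition, read by MTT assay, with a stated time of 72 h; on this read-out higher numbers stand for weaker inhibition of growth and lower numbers for stronger inhibition of growth:
compound 1 `O=S(=O)(NCCCNCc1ccccc1Cl)c1cc(C(F)(F)F)cc(C(F)(F)F)c1` gives 10000 nM;
compound 2 `O=S(=O)(NCCCCNCc1ccc(Br)cc1)c1cc(C(F)(F)F)cc(C(F)(F)F)c1` gives 2000 nM;
compound 3 `O=S(=O)(NCCCNCc1ccc(Br)cc1)c1cc(C(F)(F)F)cc(C(F)(F)F)c1` gives 2900 nM.

Compound 3 stands second highest of the three numbers in this assay. Its nearest neighbour is within the scatter, a 1.5-fold higher number from compound 2 to compound 3 (0.16 log units; within the scatter), while its furthest gap is beyond it, a 3.4-fold lower number from compound 1 to compound 3 (0.54 log units; beyond the scatter). Compound 4 `COc1ccccc1CNCCCNS(=O)(=O)c1cc(C(F)(F)F)cc(C(F)(F)F)c1` differs from compound 3 by 2-methoxyphenyl in place of 4-bromophenyl on a saturated chain carbon bound to an amine nitrogen. For the measured compounds named here, the steps that bear on this change are the two that altered the same benzyl group, a 3.4-fold lower number from compound 1 to compound 3 (0.54 log units; beyond the scatter) and a 5.0-fold lower number from compound 1 to compound 2 (0.70 log units; beyond the scatter), both beyond the scatter and both running from a 2-chlorophenyl to a 4-bromophenyl. The 2-methoxyphenyl of compound 4 resembles the 2-chlorophenyl more than the 4-bromophenyl, so the step is expected to run the other way, toward a higher number in this assay, estimated as a 2.1-fold higher number from compound 3 to compound 4 (0.32 log units; beyond the scatter). Compound 4 is therefore expected to give 6000 nM in this assay, with a range from 2500 nM to 15000 nM.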

Compound 4, concentration for 50% growth inhibition: 2400 nM
Compound 4: the middle estimate sits 2.5-fold (0.40 log units) above what was measured; the measured number lies below the stated range.
By their numbers in this assay, from the lowest: compounds 2, 4 and 3 (each within the scatter of the next); then compound 1.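

In this assay the change at this place is not uniform: methoxy in place of chloro on an aromatic carbon gives a step beyond the scatter (a 4.2-fold lower number from compound 1 to compound 4 (0.62 log units; beyond the scatter)), whereas 2-methoxyphenyl in place of 4-bromophenyl gives one within it (a 1.2-fold lower number from compound 3 to compound 4 (0.08 log units; within the scatter)). Compound 4 also stays within the scatter of the longer-chain compound (a 1.2-fold higher number from compound 2 to compound 4 (0.08 log units; within the scatter)), so among these four compounds only the 2-chlorophenyl of compound 1 stands apart, and a group in the printed 2-position of the ring does not by itself go with the higher number. Nothing measured here explains this difference between methoxy and chloro on the ring.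

Still open, as far as these compounds go, is whether compound 1 stands apart for its chloro or for where that chloro sits, which a 4-chlorophenyl or a 2-bromophenyl would help to separate. From the compounds shown here alone, how a plain phenyl or an amide in place of the amine would read also remains open.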